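Methyl removal on the oxindole-type ring of compound 3

The source may report more compounds than this note shows. Statements on the series, on what has been measured and on what is new or still open speak of the compounds shown alone.

Measured so far:
compound 1 `COc1cc2c(/C=C3/C(=O)Nc4ccc(O)cc43)c(Cl)n(Cc3cc(OC)c(OC)c(OC)c3)c2cc1C`: 50100 nM
compound 2 `COc1cc2c(/C=C3/C(=O)Nc4ccc(Cl)cc43)c(Cl)n(Cc3cc(OC)c(OC)c(OC)c3)c2cc1C`: 3890 nM
compound 3 `COc1cc2c(cc1C)NC(=O)/C2=C/c1c(Cl)n(Cc2cc(OC)c(OC)c(OC)c2)c2cc(C)c(OC)cc12`: 87100 nM

In a functional assay on cells (Cancer cell lines, Homo sapiens) for cytotoxicity, with a stated time of 48 h (a higher number here means a weaker inhibitor of growth, a lower number a stronger inhibitor of growth), compound 3 sits at the weak end of the small set. Within the data shown here, compound 3 and compound 1 lie within the scatter of each other, while compound 2 stands well apart from both; the step of a 13-fold lower number from compound 1 to compound 2 (1.11 log units; beyond the scatter) is the only one-point change measured, and it came with chloro in place of hydroxy on an aromatic carbon, a change of a different kind.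

Compound 4 `COc1ccc2c(c1)/C(=C\c1c(Cl)n(Cc3cc(OC)c(OC)c(OC)c3)c3cc(C)c(OC)cc13)C(=O)N2` differs from compound 3 by hydrogen in place of methyl on an aromatic carbon, ortho to a methoxy group, meta to a fused ring and para to a fused ring. Among the measured compounds shown here, no measured step touches a methyl at this ring, so nothing here supports a large move in either direction; the large step from compound 1 to compound 2 concerns another substituent and is not carried over.

For compound 4 the expectation is a value close to that of compound 3, with the step of a 1.2-fold lower number from compound 3 to compound 4 (0.09 log units; within the scatter) estimated to stay within the scatter. The estimate for compound 4 in this assay is 70000 nM, with a range from 25000 nM to 200000 nM.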

Compound 4, concentration for total growth inhibition: 95500 nM
Compound 4: middle estimate off by 1.4-fold (0.13 log units), on the low side, within the range that was stated.
By their numbers in this assay, from the lowest: compound 2; then compounds 1, 3 and 4 (each within the scatter of the next).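

In this assay, among these compounds, the methyl ortho to a methoxy group can be replaced by hydrogen with a 1.1-fold higher number from compound 3 to compound 4 (0.04 log units; within the scatter) and no shift beyond the scatter, the first direct reading of this position. On the same ring, methoxy and hydroxy also stay within the scatter, with a 1.9-fold higher number from compound 1 to compound 4 (0.28 log units; within the scatter) as the step, whereas chloro stands apart, with a 25-fold higher number from compound 2 to compound 4 (1.39 log units; beyond the scatter) as its step, so among the compounds shown, compound 2 alone separates from the rest. No measured data on hand bear on the reason for these steps.

Among the compounds shown here, only a single pair tests the methyl, so it remains open whether the same flat result would hold with chloro in place of the methoxy group. On these data alone, it is also open how an amine or a carboxylic acid would read at this aromatic carbon.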